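A Benzothiophene Swap at a Shared Aromatic Position

The source may report more compounds than this note shows. Statements on the series, on what has been measured and on what is new or still open speak of the compounds shown alone.

Compound 1 `Nc1ccc(S(=O)(=O)N2CCN(c3ncc(C(O)(C(F)(F)F)C(F)(F)F)cc3-c3ccccc3O)CC2)cn1`: 125 mL.min-1.g-1
Compound 2 `CS(=O)(=O)c1ccc(-c2cc(C(O)(C(F)(F)F)C(F)(F)F)cnc2N2CCN(S(=O)(=O)c3ccc(N)nc3)CC2)cc1`: 103 mL.min-1.g-1
Compound 3 `Nc1ccc(S(=O)(=O)N2CCN(c3ncc(C(O)(C(F)(F)F)C(F)(F)F)cc3-c3ccc4scnc4c3)CC2)cn1`: 147 mL.min-1.g-1

These values come from an ADME assay (liver) for metabolic stability, with Liver microsome (Rattus norvegicus) as the target, using microsomes and NADPH, with a stated time of 30 min, tested at 1 uM; a lower number here means slower removal, a higher number faster removal of the compound. The three compounds differ only in the aromatic group at one place on the shared core. Compound 3 does not stand apart from the other two, since its value of 147 mL.min-1.g-1 lies within the scatter of both.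

The next compound is compound 4 `Nc1ccc(S(=O)(=O)N2CCN(c3ncc(C(O)(C(F)(F)F)C(F)(F)F)cc3-c3cc4ccccc4s3)CC2)cn1`, where 1-benzothiophen-2-yl replaces 1,3-benzothiazol-5-yl on an aromatic carbon (1-benzothiophen-2-yl in place of 1,3-benzothiazol-5-yl on an aromatic carbon). Going by the values given here, no measured step involves the entering group itself. The exchanges at this same place do bear on it, and all three stayed within the scatter: a 1.2-fold lower number from compound 1 to compound 2 (0.08 log units; within the scatter), a 1.2-fold higher number from compound 1 to compound 3 (0.07 log units; within the scatter) and a 1.4-fold higher number from compound 2 to compound 3 (0.15 log units; within the scatter). On that basis, no change beyond the scatter is expected in this assay. The expected step is a 1.0-fold higher number from compound 3 to compound 4 (0.01 log units; within the scatter). For compound 4 the estimated value is 150 mL.min-1.g-1, with an expected range of 90 mL.min-1.g-1 to 250 mL.min-1.g-1.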

Compound 4, intrinsic clearance in microsomes: 315 mL.min-1.g-1
Compound 4: the middle estimate sits 2.1-fold (0.32 log units) below what was measured; the measured number lies above the stated range.
By their numbers in this assay, from the lowest: compounds 2, 1 and 3 (each within the scatter of the next); then compound 4.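

In this assay the aromatic group at this position no longer looks interchangeable, since 1-benzothiophen-2-yl separates from all three earlier groups, with a 2.1-fold higher number from compound 3 to compound 4 (0.33 log units; beyond the scatter) and a 3.1-fold higher number from compound 2 to compound 4 (0.49 log units; beyond the scatter) and a 2.5-fold higher number from compound 1 to compound 4 (0.40 log units; beyond the scatter) as the steps. Between compound 3 and compound 4 the heavy-atom count stays at 9, and the groups differ in the five-membered aromatic ring, with 1 hetero atom in place of 2, and in the point of attachment, yet this exchange alone moves the number beyond the scatter. Nothing available here accounts for this rise.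

The compounds shown leave open whether the step goes with the nitrogen of the five-membered ring or with the point of attachment, which a 1-benzothiophen-5-yl group at this place would separate. Going by these compounds alone, also open is whether an amine or a carboxylic acid on the benzothiophene would bring the number back towards those of the earlier compounds.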